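Changing the Sulfonyl Aryl Group in a Series of Limits

A few compounds are considered here, and "the series" means these few. Any claim that something is new, unique, unknown or untested is made for them only; others in the source may bear on it.

Three compounds share one core and differ in the aryl group on a sulfonyl sulfur. In a functional assay on KOPN-8 cells (Homo sapiens) for antiproliferative activity, with a stated time of 72 h (on this read-out lower numbers stand for an effect already at smaller amounts and higher numbers for an effect only at larger amounts of compound), compound 1 `COc1ccc(-c2cc(=O)c3c(OC)cc(OC)cc3n2S(=O)(=O)c2ccc(C=O)cc2)cc1` gives > 34400 nM, which is a limit and not a number. In this assay compound 2 `COc1ccc(-c2cc(=O)c3c(OC)cc(OC)cc3n2S(=O)(=O)c2cccc([N+](=O)[O-])c2)cc1` gives > 39600 nM, again a limit. In this assay compound 3 `COc1ccc(-c2cc(=O)c3c(OC)cc(OC)cc3n2S(=O)(=O)c2ccc(C)c([N+](=O)[O-])c2)cc1` gives > 51700 nM, also a limit. Compound 3 therefore has no exact value, and neither do the other two.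

Compound 4 `COc1ccc(-c2cc(=O)c3c(OC)cc(OC)cc3n2S(=O)(=O)c2ccc(F)cc2)cc1` has not yet been measured. It carries 4-fluorophenyl in place of 4-methyl-3-nitrophenyl on a sulfonyl sulfur.

Three measured steps change the group at this place: a step that the two limits leave unreadable from compound 1 to compound 2, a step that the two limits leave unreadable from compound 1 to compound 3 and a step that the two limits leave unreadable from compound 2 to compound 3. Among the measured compounds shown here, none of them has a size that can be carried over, so no definite step or direction can be expected in this assay. The most likely result is that compound 4 also returns only a limit. This expectation rests on compound 3, whose > 51700 nM is a limit.

The step expected here is an at least 1.2-fold lower number from compound 3 to compound 4 (0.11 log units; that floor lies within the scatter). For compound 4 the estimated value is 40000 nM, with an expected range from 10000 nM to 80000 nM.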

Compound 4, half-maximal effective concentration: > 65500 nM
Compound 4: a limit, no number; the forecaster's own chance of this, stated with the estimate: 80%; middle value at least 1.6-fold (0.21 log units) from the limit.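

Compound 4 also gives only a limit in this assay, so its steps from compound 1, compound 2 and compound 3 cannot be read. The compounds shown leave open whether any aryl group on the sulfonyl sulfur would give an exact value in this assay, and how far these four actually differ.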